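The source may hold more compounds than are shown below. What is called first, only, known or untested is meant among the compounds shown, and "the series" means these compounds.

In a functional assay on MDA-MB-435 cells (Homo sapiens) for cytotoxicity, read by MTT assay, with a stated time of 72 h (on this read-out higher numbers stand for weaker inhibition and lower numbers for stronger inhibition), the measured compounds are:

Compound 1 `Nc1ccc(Nc2c(C(=O)NCc3ccc(F)cc3)nc(Br)c3cccnc23)cc1`: 7000 nM
Compound 2 `CNCCCNc1c(C(=O)NCc2ccc(F)cc2)nc(Br)c2cccnc12`: 11000 nM
Compound 3 `O=C(NCCCNc1c(C(=O)NCc2ccc(F)cc2)nc(Br)c2cccnc12)c1ccccc1`: > 20000 nM, which is a limit of the assay rather than a number.

Compound 2 carries the highest of the two numbers shown, and compound 1 is its nearest neighbour, separated by a 1.6-fold higher number from compound 1 to compound 2 (0.20 log units; within the scatter), a step the usual scatter of this assay covers. On these data alone, the step to compound 3, an at least 1.8-fold higher number from compound 2 to compound 3 (0.25 log units; that floor lies within the scatter), runs into (the limit of > 20000 nM in this assay, at which 1 of the 3 values shown sits), so its true size is unknown.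

Compound 4 `Cc1ccc(S(=O)(=O)Oc2c(C(=O)NCc3ccc(F)cc3)nc(Br)c3cccnc23)cc1` is not yet measured. ((4-methylphenyl)sulfonyl)oxy in place of (3-(methylamino)propyl)amino on an aromatic carbon Neither measured step repeats this change: one set 3-(methylamino)propyl in place of 4-aminophenyl on a nitrogen on an aromatic ring, the other set benzoyl in place of methyl on an amine nitrogen, and both stayed within the scatter or ended at the limit. All three measured compounds sit in the weak range of this assay, so no step beyond the scatter is expected; the estimate leans toward a weaker number, as a 1.4-fold higher number from compound 2 to compound 4 (0.13 log units; within the scatter). Compound 4 is therefore estimated at 15000 nM, with a range from 5000 nM to 40000 nM, and a fair chance that this assay reports only a limit.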

Compound 4, half-maximal inhibitory concentration: > 20000 nM
Compound 4 gave a limit, no number; the forecaster's own chance of this, stated with the estimate: 45%; middle value at least 1.3-fold (0.12 log units) from the limit.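

Every compound before this one keeps a nitrogen on the aromatic carbon, whereas compound 4 joins ((4-methylphenyl)sulfonyl)oxy there through oxygen, which also brings a second six-membered aromatic ring of carbon only and leaves no hydrogen-bond donors in the group. In this assay, for the compounds shown here, the change gives an at least 2.8-fold higher number from compound 1 to compound 4 (0.45 log units; beyond the scatter), the only step so far that clears the scatter, while against the chain of compound 2 it gives an at least 1.8-fold higher number from compound 2 to compound 4 (0.25 log units; that floor lies within the scatter). Compound 4 ends at a limit of the assay rather than a number, so the true size of both steps stays unknown: the limit of > 20000 nM in this assay, at which 2 of the 4 values shown sit.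

The compounds shown leave open whether the oxygen link or the methylphenyl sulfonyl part matters more, and whether any group on this aromatic carbon can give a clearly lower number than those seen here. A hydroxyl or a methoxy group at this place would separate the link from the rest of the group, and a longer chain ending in a primary amine would extend the amino side, but the compounds shown say nothing about either.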